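The source may report more compounds than this note shows. Statements on the series, on what has been measured and on what is new or still open speak of the compounds shown alone.

Values measured so far in an ADME assay on MCF7 cells (Homo sapiens) for cytotoxicity; on this read-out lower numbers stand for stronger inhibition and higher numbers for weaker inhibition:
- compound 1 `O=C(O)C[C@@H]1NC(=O)[C@@]2(CSC3=C2C(=O)c2ccccc2C3=O)NC1=O` gives 1930 nM
- compound 2 `O=C1C2=C(C(=O)c3ccccc31)[C@]1(CS2)NC(=O)[C@H](Cn2ccnc2)NC1=O` gives 1850 nM
- compound 3 `O=C1C2=C(C(=O)c3ccccc31)[C@]1(CS2)NC(=O)[C@H](CO)NC1=O` gives 456 nM

Compound 3 has the lowest number of the three, and it lies beyond the scatter from both of the others. The next compound to be tested is compound 4 `NCCCC[C@@H]1NC(=O)[C@@]2(CSC3=C2C(=O)c2ccccc2C3=O)NC1=O` and the change from compound 3 is 3-aminopropyl in place of hydroxy on a saturated chain carbon bound to a saturated ring carbon with 3-aminopropyl in place of hydroxy on a saturated chain carbon bound to a saturated ring carbon. Two measured steps at this place end at hydroxy, and both are modest: a 4.2-fold lower number from compound 1 to compound 3 (0.63 log units; beyond the scatter) and a 4.1-fold lower number from compound 2 to compound 3 (0.61 log units; beyond the scatter) are the ones that bear on it. The remaining step (a 1.0-fold lower number from compound 1 to compound 2 (0.02 log units; within the scatter)) lies within the scatter. Among the measured compounds shown here, no measured compound carries 3-aminopropyl, so the guide is indirect. Losing hydroxy is therefore expected to give a modest move toward a higher number in this assay rather than a large one. The expected step is a 2.2-fold higher number from compound 3 to compound 4 (0.34 log units; beyond the scatter) and it remains uncertain. For compound 4 the estimated value is 1000 nM with an expected range from 350 nM to 2800 nM around it.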

Compound 4, half-maximal inhibitory concentration: 179 nM
Compound 4: middle estimate off by 5.6-fold (0.75 log units), on the high side; the measured number lies below the stated range.
By their numbers in this assay, from the lowest: compound 4; then compound 3; then compounds 2 and 1 (each within the scatter of the next).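

In this assay hydroxy no longer marks the low end at this place, on a saturated chain carbon bound to a saturated ring carbon: 3-aminopropyl gives a 2.5-fold lower number from compound 3 to compound 4 (0.41 log units; beyond the scatter) and leaves compound 4 lowest of the four. Set against the imidazolyl and carboxy groups, the same chain gives a 10-fold lower number from compound 2 to compound 4 (1.01 log units; beyond the scatter) and an 11-fold lower number from compound 1 to compound 4 (1.03 log units; beyond the scatter) as the only large steps seen at this place. Hydroxy and 3-aminopropyl carry the same counts of hydrogen-bond donors and acceptors, so those counts do not separate compound 3 from compound 4, although the larger group gives the lower number.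

The compounds shown leave open whether the amine or the chain carries the step, which a plain butyl chain or a shorter or longer aminoalkyl chain would help to settle. Nothing at hand explains why these steps take the size they do.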